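Three aryl variants measured, a fourth still to come

This account rests on a few compounds, and the source may have more. Where it says the series, first, only, none or still open, it means among the compounds named here.

Compound 1 `Cc1cc(O)c(C(C)C)cc1-c1cc(-c2ccccc2)c(C#N)c(=O)[nH]1`: 58%
Compound 2 `Cc1cc(O)c(C(C)C)cc1-c1cc(-c2cccs2)c(C#N)c(=O)[nH]1`: 63%
Compound 3 `COc1ccc(-c2cc(-c3cc(C(C)C)c(O)cc3C)[nH]c(=O)c2C#N)c(OC)c1`: 55%

In a functional assay for inhibition, tested at 80 ug/mL (on this read-out lower numbers stand for a weaker effect and higher numbers for a stronger effect at the one concentration tested), compound 1 gives 58%, and its number lies within the scatter of both neighbours: a number 5 percentage points higher from compound 1 to compound 2 (within the scatter) and a number 3 percentage points lower from compound 1 to compound 3 (within the scatter). The shared core carries one variable aryl group, and exchanging it has so far produced nothing beyond the scatter, as a number 8 percentage points lower from compound 2 to compound 3 (within the scatter) also shows.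

Compound 4 `COc1ccc(-c2cc(-c3cc(C(C)C)c(O)cc3C)[nH]c(=O)c2C#N)cc1OC` differs from compound 1 as follows: 3,4-dimethoxyphenyl in place of phenyl on an aromatic carbon. The step bearing most closely on it is that to compound 3, where a second dimethoxyphenyl pattern gave a number 3 percentage points lower from compound 1 to compound 3 (within the scatter). A step of similar size is therefore expected, a number 3 percentage points lower from compound 1 to compound 4 (within the scatter), with no direction beyond the scatter. Compound 4 is estimated at 55%, ranging from 40% to 70%.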

Compound 4, a percentage reported as inhibition, at one concentration (the size of the read-out at that concentration, not a potency): 58%
The estimate for compound 4 lay 3 percentage points below the measured number; the measured number falls inside the stated range.
By their numbers in this assay, from the lowest: compounds 3, 1, 4 and 2 (each within the scatter of the next).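

In this assay, the 3,4-dimethoxyphenyl group, with 10 heavy atoms and 2 hydrogen-bond acceptors, leaves the read-out unmoved relative to phenyl at this carbon ortho to a cyano group (no change at the digits printed from compound 1 to compound 4 (within the scatter)). Moving from the 2,4-dimethoxyphenyl pattern to the 3,4-dimethoxyphenyl pattern stays within the scatter (a number 3 percentage points higher from compound 3 to compound 4 (within the scatter)), as does the exchange with thiophen-2-yl (a number 5 percentage points lower from compound 2 to compound 4 (within the scatter)). No measurement shown explains this flat response.

From the compounds shown here alone, all four variable groups are aromatic rings, so the effect of an amine, a carboxylic acid or a longer alkyl chain here remains open. Potency also remains open, as each number comes from a single concentration.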